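The source may hold more compounds than are shown below. What is called first, only, known or untested is meant among the compounds shown, and "the series" means these compounds.

In a functional assay on K562 cells (Homo sapiens) for antiproliferative activity, read by MTT assay, with a stated time of 48 h (on this read-out lower numbers stand for stronger inhibition and higher numbers for weaker inhibition), compound 1 (`CCN(CC)CCn1c(N)c(-c2nc3ccccc3[nH]2)c2nc(C#N)c(C#N)nc21`) gives 2490 nM and compound 3 (`N#Cc1nc2c(-c3nc4ccccc4[nH]3)c(N)n(CCCN3CCCCC3)c2nc1C#N`) gives 3460 nM. These two numbers lie within the scatter of each other, as the step shows: a 1.4-fold higher number from compound 1 to compound 3 (0.14 log units; within the scatter). Compound 2 (`N#Cc1nc2c(-c3nc4ccccc4[nH]3)c(N)n(CCCO)c2nc1C#N`) reads > 50000 nM, which is a limit of the assay. Compound 4 (`CCN(CC)CCn1c(N)c(-c2nc3ccccc3n2C)c2nc(C#N)c(C#N)nc21`) keeps the diethylamino chain of compound 1 and differs as follows: methyl in place of hydrogen on an aromatic nitrogen. That is methyl in place of hydrogen on an aromatic nitrogen. For the measured compounds named here, no measured step touches that nitrogen. The available steps, an at least 20-fold higher number from compound 1 to compound 2 (1.30 log units; beyond the scatter) and a 1.4-fold higher number from compound 1 to compound 3 (0.14 log units; within the scatter), concern only the chain and bear on it indirectly. A moderate step toward a higher number is therefore expected in this assay, with low confidence. The estimate for compound 4 is 5000 nM, with an expected range of 1800 nM to 20000 nM. This would be an expected 2.0-fold higher number from compound 1 to compound 4 (0.30 log units; within the scatter).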

Compound 4, half-maximal inhibitory concentration: > 50000 nM
Compound 4: a limit, no number (the forecaster's own chance of this, stated with the estimate: 10%); middle value at least 10-fold (1.00 log units) from the limit.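

Methyl in place of hydrogen on the aromatic nitrogen of the 1H-benzimidazol-2-yl group is the first change away from the chain, and in this assay it gives an at least 20-fold higher number from compound 1 to compound 4 (1.30 log units; beyond the scatter). A single added carbon at this nitrogen is therefore enough to lose measurable activity, even with the diethylamino chain kept. The true size of the step remains unknown, compound 4 being at a limit of the assay: the limit of > 50000 nM in this assay, at which 2 of the 4 values shown sit.

Still open, from the compounds shown here alone, is how an ethyl group or an acetyl group on this nitrogen would read. Also open, going by these compounds, is whether the same methyl would have a comparable effect alongside the piperidin-1-yl chain of compound 3.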